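The source may report more compounds than this note shows. Statements on the series, on what has been measured and on what is new or still open speak of the compounds shown alone.

The measured compounds:
compound 1, `CC1=CCCC(C)(C)C1/C=C/C(=O)/C=C/c1ccccc1F`, gives 8300 nM in a functional assay on PCa 2b cells (Homo sapiens) for cytotoxicity, read by MTT assay, with a stated time of 72 h; on this read-out lower numbers stand for stronger inhibition and higher numbers for weaker inhibition;
compound 2, `CC1=CCCC(C)(C)C1/C=C/C(=O)/C=C/c1cc(C(F)(F)F)ccc1F`, gives 3000 nM;
compound 3, `CC1=C(/C=C/C(=O)/C=C/c2ccccc2)C(C)(C)CCC1O`, gives 12600 nM.

Compound 2 differs from compound 1 by one change, (trifluoromethyl in place of hydrogen on an aromatic carbon). That change brought a 2.8-fold lower number from compound 1 to compound 2 (0.44 log units; beyond the scatter). Compound 3 is built on a different core from compound 1; the difference between the two cores is not broken down here. Compound 3 has the highest number of the three, though its gap to compound 1 lies within the scatter.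

Compound 4, `CC1=C(/C=C/C(=O)/C=C/c2ccc(C(F)(F)F)cc2)C(C)(C)CCC1O`, is not yet measured. It differs from compound 3 by trifluoromethyl in place of hydrogen on an aromatic carbon. Among the measured compounds shown here, this is the same kind of change as the one between compound 1 and compound 2, but not the same: in compound 2 the trifluoromethyl sits meta to a large group and para to a fluoro group, while in compound 4 it sits para to a large group. The expected step is a 2.1-fold lower number from compound 3 to compound 4 (0.32 log units; beyond the scatter) in this assay, a little smaller than the earlier one, because the step of a 2.8-fold lower number from compound 1 to compound 2 (0.44 log units; beyond the scatter) was made at a different place. In this assay compound 4 is estimated at 6000 nM, expected to lie between 3000 nM and 12000 nM.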

Compound 4, half-maximal inhibitory concentration: 9300 nM
Beside the measured number, compound 4's estimate is 1.6-fold (0.19 log units) below it; low and high end bracket the measured number.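

In this assay, among the compounds shown here, putting trifluoromethyl in place of hydrogen on the core of compound 3 gives a 1.4-fold lower number from compound 3 to compound 4 (0.13 log units; within the scatter), so on this core the change produces no step that can be told apart from ordinary repeat-to-repeat variation. This looks weaker than the step on the first core, yet the two steps cannot be called different: the same change on two cores in this assay, a 2.8-fold lower number (0.44 log units; beyond the scatter) from compound 1 to compound 2 and a 1.4-fold lower number (0.13 log units; within the scatter) from compound 3 to compound 4, 2.0-fold (0.31 log units) apart, within the scatter of two such steps. For the compounds shown here, the result therefore does not show that the gain seen on the first core carries over, nor does it show that the gain is lost, since each core offers only one pair and the trifluoromethyl also sits at a different place on the aromatic ring in the two pairs.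

The compounds shown leave open whether trifluoromethyl at the same ring place on both cores would give matching steps, which would separate the effect of the core from that of the place. They also leave open how a chlorine atom, a methoxy group or a carboxylic acid at that ring carbon would compare.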